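Enaminone chalcones with arylamino thiazole: ortho-methyl swap

A few compounds are considered here, and "the series" means these few. Any claim that something is new, unique, unknown or untested is made for them only; others in the source may bear on it.

Measured so far:
compound 1 `COc1cccc(/C=C/C(=O)c2sc(Nc3ccccc3C)nc2C)c1` — > 25000 nM
compound 2 `Cc1ccc(Nc2nc(C)c(C(=O)/C=C/c3ccccc3Cl)s2)cc1` — > 25000 nM

In a functional assay on BGC-823 cells (Homo sapiens) for cytotoxicity, read by MTT assay (a higher number here means a weaker inhibitor, a lower number a stronger inhibitor), compound 2 gives > 25000 nM, which is a limit of the assay and not a number. Compound 1 likewise sits at a limit in this assay, > 25000 nM. Among the compounds with values here, both values therefore stand at the limit of > 25000 nM in this assay, at which 2 of the 2 values shown sit, and no measured step between the two compounds can be counted.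

Compound 3 `Cc1ccccc1Nc1nc(C)c(C(=O)/C=C/c2ccccc2Cl)s1` is not yet measured. It differs from compound 2 by 2-methylphenyl in place of 4-methylphenyl on a nitrogen on an aromatic ring; the same atoms are present, joined differently. No step between measured compounds is shown, so the size of this change in this assay is not known from the series itself. Compound 1, which carries the same 2-methylphenyl group on that nitrogen, stands at a limit > 25000 nM, and compound 2 stands at a limit too. The expectation is therefore no shift beyond the scatter, with compound 3 most likely also reported only as a limit. For compound 3 the estimate is 30000 nM in this assay, in the range 10000 nM to 100000 nM. The expected step that the limit leaves unreadable from compound 2 to compound 3 is essentially flat.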

Compound 3, half-maximal inhibitory concentration: > 25000 nM
Compound 3 ended at the assay's limit; the forecaster's own chance of this, stated with the estimate: 85%; the middle value does not contradict the limit.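

In this assay compound 3 gives > 25000 nM, a limit of the assay and not a number. The steps to compound 3 from compound 1 and compound 2 cannot be read: the limit of > 25000 nM in this assay, at which 3 of the 3 values shown sit.

The compounds shown leave open how 2-methylphenyl and 4-methylphenyl compare, and whether any member of the series gives a readable value.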